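Replacing fluoro with hydrogen on compound 1

A few compounds are considered here, and "the series" means these few. Any claim that something is new, unique, unknown or untested is made for them only; others in the source may bear on it.

Three compounds measured so far in a toxicity assay on HUVEC cells (Homo sapiens) for inhibition; a lower number here means a stronger inhibitor of growth, a higher number a weaker inhibitor of growth
- Compound 1 `COc1cc(OC)cc(N2CCN(C(=O)c3oc(C)nc3-c3ccccc3F)CC2)c1` gives (0.118 ug/mL)
- Compound 2 `CCC[C@H](Nc1nc(-c2ccc(NC(=O)NCC)c(OC)c2)ncc1C)c1cccnc1` gives (2.1 ug/mL)
- Compound 3 `Cc1nc(-c2cccc(F)c2)c(C(=O)N2CCN(c3cc(Cl)cc(Cl)c3)CC2)o1` gives (0.134 ug/mL)

Compound 1 and compound 3 sit together at the low end of these numbers, within the usual scatter of each other. Compound 2 stands at a higher number, beyond that scatter.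

Compound 4 (`COc1cc(OC)cc(N2CCN(C(=O)c3oc(C)nc3-c3ccccc3)CC2)c1`) has not yet been measured. It carries hydrogen in place of fluoro on an aromatic carbon, ortho to a large group (hydrogen in place of fluoro on an aromatic carbon), so that 2-fluorophenyl becomes phenyl.

Among the measured compounds shown here, no measured pair isolates this change, so the expectation rests on limited evidence. Compound 3 (0.134 ug/mL) stays within the scatter of compound 1 (0.118 ug/mL), although the two differ in more than one place. The expected step (a 1.2-fold higher number from compound 1 to compound 4 (0.07 log units; within the scatter)) is therefore none beyond the scatter, with only a slight rise in the number. Compound 4 is estimated at 0.14 ug/mL in this assay (expected range 0.07 ug/mL to 0.32 ug/mL).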

Compound 4, concentration for 50% growth inhibition: 0.319 ug/mL
Estimate against measurement, compound 4: 2.3-fold (0.36 log units) below; the range from low to high includes it.
By their numbers in this assay, from the lowest: compounds 1 and 3 (each within the scatter of the next); then compound 4; then compound 2.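

In this assay, among the compounds shown here, this pair gives the first direct reading of this position: going from 2-fluorophenyl to phenyl brings a 2.7-fold higher number from compound 1 to compound 4 (0.43 log units; beyond the scatter). The earlier compounds shown here held no pair differing in this one place, so only now can it be seen that a single fluoro on this aromatic carbon, ortho to a large group, makes a modest but real difference, with the fluoro-bearing compound the stronger inhibitor of growth. Nothing available here accounts for the step.

The compounds shown leave open whether the advantage belongs to fluoro alone or would also appear with another group at this place, such as a nitrile or trifluoromethyl. A single pair also cannot say whether the same change would give a step of similar size on any other compound.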